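The source may hold more compounds than are shown below. What is called first, only, known or untested is meant among the compounds shown, and "the series" means these compounds.

Going by the values given here, compound 2 `O=C(O)c1csc(SCCN2C(=O)CC[C@@H]2/C=C/[C@@H](O)Cc2cccc(-c3ccccc3)c2)n1` gives 3 nM in an assay on CHO cells for displacement of a labelled ligand from prostaglandin E2 receptor EP2 subtype (Mus musculus), read by scintillation counting, with a stated time of 60 min (on this read-out lower numbers stand for stronger inhibition and higher numbers for weaker inhibition), the lower of the two numbers so far in hand. Compound 1 `O=C(O)CCCSCCN1C(=O)CC[C@@H]1/C=C/[C@@H](O)Cc1cccc(-c2nc3ccccc3s2)c1` differs from compound 2 in several places. In this assay compound 1 gives 720 nM, a far higher number and well beyond the scatter; since no single change separates these two compounds, their values can only be set side by side. Compound 3 `Cc1cc(C)c2oc(-c3cccc(C[C@H](O)/C=C/[C@H]4CCC(=O)N4CCSc4nc(C(=O)O)cs4)c3)nc2c1` has not yet been measured. It differs from compound 2 by one change: 5,7-dimethyl-1,3-benzoxazol-2-yl in place of phenyl on an aromatic carbon. Compound 1 carries a larger aromatic group in the same region together with a different acid chain, so it offers no clean comparison. The expected step of a 2.0-fold higher number from compound 2 to compound 3 (0.30 log units; within the scatter) is modest, most likely toward a somewhat higher number. The estimate for compound 3 in this assay is 6 nM, with a range from 1.5 nM to 40 nM.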

Compound 3, inhibition constant: 24 nM
Compound 3: middle estimate off by 4.0-fold (0.60 log units), on the low side; the range from low to high includes it.
By their numbers in this assay, from the lowest: compound 2; then compound 3; then compound 1.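

In this assay, replacing phenyl with 5,7-dimethyl-1,3-benzoxazol-2-yl on this aromatic carbon, meta to a large group, gives an 8.0-fold higher number from compound 2 to compound 3 (0.90 log units; beyond the scatter), a change beyond the usual scatter. Going by these compounds alone, this is the first one-place reading at this position, and it shows that the larger two-ring group, which brings hydrogen-bond acceptors that phenyl lacks, is accepted there at a measurable cost in binding. Nothing available explains this loss or ties it to any one feature of the entering group.

The compounds shown do not separate the contribution of the two methyl groups from that of the fused ring, which unsubstituted 1,3-benzoxazol-2-yl would address. They also leave open how a single-ring replacement such as pyridyl or thiazolyl would behave at this position.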